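Swap of the ring-nitrogen aryl group in the thiazolidinone series

This account rests on a few compounds, and the source may have more. Where it says the series, first, only, none or still open, it means among the compounds named here.

Of the compounds shown here, three of one series have been tested in a functional assay on HOS-TE85 cells (Homo sapiens) for inhibition, read by CCK-8 assay, with a stated time of 72 h, tested at 1 uM; a lower number here means less inhibition, a higher number more inhibition at the concentration tested (going by the name of the read-out). Compound 1 `COc1ccc(OC)c(N2C(=O)CSC2c2cccc(C(=O)NCCCCc3ccccc3)c2)c1` gives 20%. Compound 2 `O=C(NCCCCc1ccccc1)c1cccc(C2SCC(=O)N2c2cccc(F)c2)c1` gives 94%. Within the data shown here, compound 3 `COc1cc(F)ccc1N1C(=O)CSC1c1cccc(C(=O)NCCCCc2ccccc2)c1` gives 94%, level with compound 2 and together with it the highest of the three numbers; the only lower value is that of compound 1, which sits a number 74 percentage points higher from compound 1 to compound 3 (beyond the scatter).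

Two measured steps change the aryl group on the amide-type nitrogen in the ring: a number 74 percentage points higher from compound 1 to compound 2 (beyond the scatter) and a number 74 percentage points higher from compound 1 to compound 3 (beyond the scatter), both large. The third, no change at the digits printed from compound 2 to compound 3 (within the scatter), shows that a fluorophenyl and a fluoro-methoxyphenyl on that nitrogen give the same read-out within the scatter.

Compound 4 `CC(F)(F)c1cccc(N2C(=O)CSC2c2cccc(C(=O)NCCCCc3ccccc3)c2)c1` is the next step from compound 3: a group of 10 heavy atoms (8 carbon, 2 fluorine; one six-membered aromatic ring of carbon only) in place of a group of 9 heavy atoms (7 carbon, 1 oxygen, 1 fluorine; one six-membered aromatic ring of carbon only), on an amide-type nitrogen in a ring. The entering group keeps a six-membered aromatic ring of carbon only and carries fluorine, as do the groups of compound 2 and compound 3; it loses the one hydrogen-bond acceptor. Among the measured compounds shown here, the only large steps seen come from leaving the dimethoxyphenyl of compound 1, and between the two fluorine-bearing aryl groups no change was seen, so for compound 4 the expected step is a number 8 percentage points lower from compound 3 to compound 4 (within the scatter), within the scatter or at most a modest drop. Compound 4 is therefore estimated at 86% with a range from 60% to 97%.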

Compound 4, a percentage reported as inhibition, at one concentration (the size of the read-out at that concentration, not a potency): 93%
Beside the measured number, compound 4's estimate is 7 percentage points below it; the measured number falls inside the stated range.
By their numbers in this assay, from the lowest: compound 1; then compounds 4, 2 and 3 (each within the scatter of the next).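

In this assay, the aryl group on the amide-type nitrogen can lose its hydrogen-bond acceptor and its oxygen without a step beyond the scatter, as a number 1 percentage points lower from compound 3 to compound 4 (within the scatter) shows, so the methoxy group of compound 3 is not required for this read-out. The aryl substituent can also be larger than a single fluoro: 1,1-difluoroethyl in place of fluoro gives a number 1 percentage points lower from compound 2 to compound 4 (within the scatter), while leaving the 2,5-dimethoxyphenyl of compound 1 again gives a large step, a number 73 percentage points higher from compound 1 to compound 4 (beyond the scatter), now the third such step from that compound. No measurement given here accounts for the low value of compound 1 or for the level read-out of the other three compounds.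

Compounds 2, 3 and 4 are not separated at the single concentration tested, so a ranking among them would need data at lower concentrations. It also remains open whether fluorine on the aryl group matters at all, and how a plain phenyl, a dimethylamino group or a carboxylic acid on that ring would read out, as each would test this position with a group unlike those shown.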